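The source may hold more compounds than are shown below. What is called first, only, known or untested is meant among the compounds shown, and "the series" means these compounds.

Compound 1 `COc1cc(-c2nn(-c3cccc(NC(=O)c4cccc(C(F)(F)F)c4)c3)cc2-c2ccncc2)ccc1Cl` carries an amide on the shared core, and in a functional assay on MOLT-4 cells (Homo sapiens) for inhibition, read by sulforhodamine B assay, with a stated time of 48 h (on this read-out higher numbers stand for lower toxicity in this test and lower numbers for higher toxicity in this test), compound 1 gives > 50000 nM, which is a limit of the assay rather than a number. Two related ureas on the same core are also measured. Compound 2 `O=C(Nc1cccc(-n2cc(-c3ccncc3)c(-c3ccc(Cl)c(O)c3)n2)c1)Nc1cc(C(F)(F)F)cc(C(F)(F)F)c1` gives in this assay > 50000 nM, again a limit of the assay. Compound 3 `O=C(Nc1cccc(-n2cc(-c3ccncc3)c(-c3ccc(Cl)c(O)c3)n2)c1)Nc1ccc(Cl)c(C(F)(F)F)c1` gives in this assay > 32500 nM, also a limit of the assay. Thus every value shown, including that of compound 1, sits at a limit: the limit of > 50000 nM in this assay, at which 2 of the 3 values shown sit, and the limit of > 32500 nM in this assay, at which 1 of the 3 values shown sits, describe all three. For the measured compounds named here, no step between measured compounds can be given.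

Compound 4 `COc1cc(-c2nn(-c3cccc(NC(=O)Nc4ccc(Cl)c(Cl)c4)c3)cc2-c2ccncc2)ccc1Cl` differs from compound 1 in one place: (3,4-dichlorophenyl)amino in place of 3-(trifluoromethyl)phenyl on a carbonyl carbon. The change turns the amide of compound 1 into a urea of the kind found in compound 2 and compound 3, whose values are limits. No step beyond the scatter is expected, and the step from compound 1 to compound 4 in this assay is estimated as a number no higher from compound 1 to compound 4 (the limit leaves the size open). Compound 4 is therefore expected to give about 50000 nM in this assay, within a range of 20000 nM to 100000 nM, most likely again reported only as a limit.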

Compound 4, concentration lethal to 50% of the cells: > 50000 nM
Compound 4: only a limit was reported; the forecaster's own chance of this, stated with the estimate: 85%; the middle value lies on the limit itself.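

Compound 4, like compound 1, is reported only as a limit in this assay, and the step between the two cannot be read. The compounds shown leave open whether (3,4-dichlorophenyl)amino in place of 3-(trifluoromethyl)phenyl on a carbonyl carbon changes the read-out at all.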